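Predicting Compound 4 From a Swap Already Seen Once

The source may report more compounds than this note shows. Statements on the series, on what has been measured and on what is new or still open speak of the compounds shown alone.

Of the compounds shown here, three have been measured in a functional assay on PC-3 cells (Homo sapiens) for cytotoxicity, read by MTT assay, with a stated time of 72 h; on this read-out higher numbers stand for weaker inhibition and lower numbers for stronger inhibition.

Compound 1, `COc1cc(Nc2nc3ccccc3nc2S(=O)(=O)c2ccccc2)cc(OC)c1`, gives 140 nM.
Compound 2, `Nc1ccc(Nc2nc3ccccc3nc2S(=O)(=O)c2ccccc2)cc1`, gives 5830 nM.
Compound 3, `COc1cc(Nc2nc3ccccc3nc2S(=O)(=O)c2ccc(Br)cc2)cc(OC)c1`, gives 18200 nM.

All three share one core and differ in only two spots. Going from compound 1 to compound 2 the change is 4-aminophenyl in place of 3,5-dimethoxyphenyl on a nitrogen on an aromatic ring, and in this assay this shows as a 42-fold higher number from compound 1 to compound 2 (1.62 log units; beyond the scatter). Going from compound 1 to compound 3 the change is bromo in place of hydrogen on an aromatic carbon, which shows as a 130-fold higher number from compound 1 to compound 3 (2.11 log units; beyond the scatter). Compound 3 thus stands at the high end of the three numbers, well separated from the other two.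

Compound 4, `Nc1ccc(Nc2nc3ccccc3nc2S(=O)(=O)c2ccc(Br)cc2)cc1`, has not yet been measured. It differs from compound 3 by 4-aminophenyl in place of 3,5-dimethoxyphenyl on a nitrogen on an aromatic ring. Among the measured compounds shown here, this is the same change as the one from compound 1 to compound 2, made at the same place: the two place descriptions agree word for word, while the two cores differ by bromo in place of hydrogen on an aromatic carbon. If the swap acts as it did before, compound 4 is expected to show a step of about an 11-fold higher number from compound 3 to compound 4 (1.04 log units; beyond the scatter) in this assay. That expectation rests on a 42-fold higher number from compound 1 to compound 2 (1.62 log units; beyond the scatter), now applied to the value of compound 3. Because compound 3 already gives 18200 nM, such a step is expected to carry compound 4 to a markedly higher number still. The estimate for compound 4 is 200000 nM, expected to lie between 40000 nM and 800000 nM.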

Compound 4, half-maximal inhibitory concentration: 2330 nM
Beside the measured number, compound 4's estimate is 86-fold (1.93 log units) above it; the whole stated range lies above it.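

Carrying the swap from 3,5-dimethoxyphenyl to 4-aminophenyl onto the bromo core did not repeat the earlier result in this assay. Instead of another rise, it gave a 7.8-fold lower number from compound 3 to compound 4 (0.89 log units; beyond the scatter), so the same change moved the number in the opposite direction on the two cores: the same change on two cores in this assay, a 42-fold higher number (1.62 log units; beyond the scatter) from compound 1 to compound 2 and a 7.8-fold lower number (0.89 log units; beyond the scatter) from compound 3 to compound 4, 330-fold (2.51 log units) apart, beyond the scatter of two such steps

The bromo change fails to carry over in the same way, since on the 4-aminophenyl side it gives a 2.5-fold lower number from compound 2 to compound 4 (0.40 log units; beyond the scatter), whereas on the 3,5-dimethoxyphenyl side the number rose: the same change on two cores in this assay, a 130-fold higher number (2.11 log units; beyond the scatter) from compound 1 to compound 3 and a 2.5-fold lower number (0.40 log units; beyond the scatter) from compound 2 to compound 4, 330-fold (2.51 log units) apart, beyond the scatter of two such steps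

These four compounds therefore show that the two changes do not act independently here, so a step measured on one core could not be transferred to the other, but they do not show why this happens or whether the same holds beyond this set.

On these data alone, it remains open whether the sharp rise seen with bromo on the 3,5-dimethoxyphenyl side is particular to bromine or would also appear with chloro or methyl in its place. As far as these compounds go, it is equally open whether a different group on the nitrogen, such as 4-hydroxyphenyl or plain phenyl, would follow compound 2 and compound 4 or follow compound 1 and compound 3.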